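A few compounds are considered here, and "the series" means these few. Any claim that something is new, unique, unknown or untested is made for them only; others in the source may bear on it.

Compound 1 `C/C=C1/[C@H](O[C@@H]2O[C@H](COC(C)=O)[C@@H](OC(C)=O)[C@H](OC(C)=O)[C@H]2OC(C)=O)OC=C(C(=O)OC)[C@H]1CC(=O)OCCCCCCCCCCCCCCC` carries a long saturated ester chain and a fully acetylated sugar; in a functional assay on SK-BR-3 cells (Homo sapiens) for antiproliferative activity, read by MTT assay, with a stated time of 72 h (a lower number here means a stronger inhibitor, a higher number a weaker inhibitor), compound 1 gives 3810 nM. Compound 2 `C/C=C1/[C@H](O[C@@H]2O[C@H](CO)[C@@H](O)[C@H](O)[C@H]2O)OC=C(C(=O)OC)[C@H]1CC(=O)OCCc1ccc(OC)c(OC)c1` has the free sugar and a 2-(3,4-dimethoxyphenyl)ethyl ester. In this assay compound 2 reaches only the upper limit of the measurement, > 15000 nM, and so sits at the limit of > 15000 nM in this assay, at which 1 of the 2 values shown sits, with no number of its own. Within the data shown here, no step between measured compounds can be drawn here, since the two differ in more than one place.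

Compound 3 `C/C=C1/[C@H](O[C@@H]2O[C@H](CO)[C@@H](O)[C@H](O)[C@H]2O)OC=C(C(=O)OC)[C@H]1CC(=O)OCCc1ccc(O)cc1` differs from compound 2 in a single place: 4-hydroxyphenyl in place of 3,4-dimethoxyphenyl on a saturated chain carbon, two bonds along the chain from an oxygen next to a carbonyl group. Starting from a limit, there is no measured step in this assay to lean on, and the change is a small one at the far end of the ester chain. Compound 3 is therefore expected to stay near the limit, with the step from compound 2 estimated as a step that the limit leaves unreadable from compound 2 to compound 3. The expected value for compound 3 is 18000 nM, within a range from 6000 nM to 50000 nM.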

Compound 3, half-maximal inhibitory concentration: > 20000 nM
Compound 3: no number, only a limit; the forecaster's own chance of this, stated with the estimate: 65%; middle value at least 1.1-fold (0.04 log units) from the limit.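

In this assay compound 3 gives only a limit, > 20000 nM, and no number. Among these compounds, compound 2 is also a limit, so no step between compound 2 and compound 3 can be read. The compounds shown leave open whether 4-hydroxyphenyl in place of 3,4-dimethoxyphenyl changes the activity at all.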